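A few compounds are considered here, and "the series" means these few. Any claim that something is new, unique, unknown or untested is made for them only; others in the source may bear on it.

Measured in a physicochemical assay for lipophilicity; a lower number here means a more polar compound, a higher number a more lipophilic compound:
- compound 1 `O=S(=O)(Nc1ncccn1)c1ccc2c(c1)OCC[C@@H]2c1ccc(C(F)(F)F)cc1-c1ccc(F)nc1`: 2.8
- compound 2 `Cn1nccc1-c1cc(C(F)(F)F)ccc1[C@H]1CCOc2cc(S(=O)(=O)Nc3ncccn3)ccc21`: 3.7

Of these two numbers, compound 2 holds the higher one. Compound 3 `Cn1nccc1-c1cc(C(F)(F)F)ccc1[C@H]1CCOc2cc(S(=O)(=O)Nc3cccnn3)ccc21` differs from it in one place: pyridazin-3-yl in place of pyrimidin-2-yl on a sulfonamide nitrogen. It has pyridazin-3-yl in place of pyrimidin-2-yl on a sulfonamide nitrogen, so the two have the same atoms, joined differently. Within the data shown here, only one measured step exists, a number 0.90 log units higher from compound 1 to compound 2 (beyond the scatter), a modest one beyond the scatter. It involves 1-methyl-1H-pyrazol-5-yl and 6-fluoropyridin-3-yl on an aromatic carbon, so it bears only loosely on this change. Among the measured compounds shown here, no measured step alters the group on the sulfonamide nitrogen. The expectation therefore starts from compound 2 at 3.7 and foresees no step beyond the scatter in this assay. The expected result is a number 0.10 log units lower from compound 2 to compound 3 (within the scatter). For compound 3 the estimated value is 3.6, with an expected range from 3 to 4.1.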

Compound 3, distribution coefficient: 2.2
For compound 3 the middle estimate is 1.40 log units above the measured one, and the stated range ends above it.
By their numbers in this assay, from the lowest: compound 3; then compound 1; then compound 2.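

On the sulfonamide nitrogen, in this assay, exchanging pyrimidin-2-yl for pyridazin-3-yl gives a number 1.50 log units lower from compound 2 to compound 3 (beyond the scatter). The two groups have the same heavy atoms, ring size, and counts of hydrogen-bond donors and acceptors, so a large step arises here without any change in those counts, and this position had not been probed by the earlier step, which lay on an aromatic carbon. Nothing available explains the size of this step.

As far as these compounds go, it remains open whether pyridazin-3-yl would give a step of similar size when 6-fluoropyridin-3-yl replaces 1-methyl-1H-pyrazol-5-yl on the aromatic carbon. Also open, from the compounds shown here alone, is where pyrazin-2-yl or pyridin-2-yl on the sulfonamide nitrogen would fall in this assay.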